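Thiazole Amide Series: Efficacy at the Free Fatty Acid Receptor

The compounds below may be only part of what the source reports. "The series", "measured", "known", "first", "only" and "open" are said of these compounds alone.

Two compounds of this series have a measured value. Compound 1 `Cc1csc(NC(=O)[C@H](c2ccc(Cl)cc2)C(C)C)n1` gives, in a functional assay on CHO cells for agonist activity at Free fatty acid receptor 2 (Homo sapiens), read by cAMP accumulation (on this read-out lower numbers stand for smaller maximal responses and higher numbers for larger maximal responses), 87%. Compound 2 `CC(C)(C)[C@H](C(=O)Nc1ncc(Br)s1)c1ccc(Cl)cc1` gives in this assay 95%, the higher of the two numbers, though the gap to compound 1 is within the scatter of the assay, so the two are not told apart. Among the measured compounds shown here, no step between compounds differing in one place has been recorded, so nothing shows how a change on the thiazole ring moves the maximal response.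

Compound 3 `CC(C)(C)[C@H](C(=O)Nc1ncc(C(O)(C(F)(F)F)C(F)(F)F)s1)c1ccc(Cl)cc1` is not yet measured. It differs from compound 2 as follows: 2,2,2-trifluoro-1-hydroxy-1-(trifluoromethyl)ethyl in place of bromo on an aromatic carbon. The bromo and the entering group both sit next to the ring sulfur. Given that both measured compounds reach a high maximal response, the step in this assay from compound 2 to compound 3 is expected to be small, with some room for a downward move, a step of a number 10 percentage points lower from compound 2 to compound 3 (within the scatter). For compound 3 the expected value in this assay is 85%, in the range 55% to 105%.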

Compound 3, largest response reached (reported as efficacy), in percent of the reference or control that the assay uses: 113%
Beside the measured number, compound 3's estimate is 28 percentage points below it, and the stated range ends below it.
By their numbers in this assay, from the lowest: compounds 1 and 2 (each within the scatter of the next); then compound 3.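

In this assay, among the compounds shown here, putting 2,2,2-trifluoro-1-hydroxy-1-(trifluoromethyl)ethyl in place of bromo on the aromatic carbon next to the ring sulfur gives a number 18 percentage points higher from compound 2 to compound 3 (beyond the scatter) and is the first step that can be read. For the compounds shown here, the position therefore takes a much larger group, with 10 heavy atoms entering for 1 and a hydrogen-bond donor and acceptor entering where bromo has neither, and the maximal response rises rather than falls, with compound 3 at 113% as the highest number so far. Nothing measured here bears on why the response moves this way.

On these data alone, this single change does not separate the hydroxyl from the two trifluoromethyl groups, so it remains open whether a plain hydroxymethyl, an amine or a carboxylic acid on the same carbon would hold the maximal response. As far as these compounds go, it also remains open whether the same replacement would move the response in the same direction on the core of compound 1, which carries a methyl on the ring and a smaller branched chain on the amide side.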